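A few compounds are considered here, and "the series" means these few. Any claim that something is new, unique, unknown or untested is made for them only; others in the source may bear on it.

Measured so far in a functional assay on A549 cells (Homo sapiens) for inhibition, read by sulforhodamine B assay, with a stated time of 48 h, tested at 50 uM; on this read-out higher numbers stand for more inhibition of growth at the one concentration tested and lower numbers for less inhibition of growth:
Compound 1 `COc1ccc([C@@H]2C/C(=N/OCc3cn(-c4ccc(Cl)cc4C)nn3)c3cc(CC=C(C)C)c(OC)cc3O2)cc1`: compound 1 gives 35%.
Compound 2 `COc1ccc([C@@H]2C/C(=N/OCc3cn(-c4ccc(O)cc4)nn3)c3cc(CC=C(C)C)c(OC)cc3O2)cc1`: compound 2 gives 52%.
Compound 3 `COc1ccc([C@@H]2C/C(=N/OCc3cn(-c4cc(OC)c(OC)c(OC)c4)nn3)c3cc(CC=C(C)C)c(OC)cc3O2)cc1`: compound 3 gives 28%.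

Compound 3 stands lowest of the three numbers; its gap to compound 1 lies within the scatter, its gap to compound 2 beyond it. All three differ only in the group on the aromatic nitrogen, and the measured steps there are a number 17 percentage points higher from compound 1 to compound 2 (beyond the scatter), a number 7 percentage points lower from compound 1 to compound 3 (within the scatter) and a number 24 percentage points lower from compound 2 to compound 3 (beyond the scatter).

Compound 4 `COc1ccc([C@@H]2C/C(=N/OCc3cn(-c4cccnc4Cl)nn3)c3cc(CC=C(C)C)c(OC)cc3O2)cc1` is not yet measured. The change: 2-chloropyridin-3-yl in place of 3,4,5-trimethoxyphenyl on an aromatic nitrogen. All three measured steps bear on this same position. The only clear rise came with the 4-hydroxyphenyl of compound 2; the entering 2-chloropyridin-3-yl carries chlorine, as does the 4-chloro-2-methylphenyl of compound 1, and compound 1 sits near compound 3 because a number 7 percentage points lower from compound 1 to compound 3 (within the scatter). A small step is therefore expected, not clearly beyond the scatter, if anything upward.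

Compound 4 is expected to give 35%, within 15% to 55%. This corresponds to an expected change of a number 7 percentage points higher from compound 3 to compound 4 (within the scatter).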

Compound 4, percent growth inhibition at one concentration: 58%
For compound 4 the middle estimate is 23 percentage points below the measured one; measured number outside the range, above it.
By their numbers in this assay, from the lowest: compounds 3 and 1 (each within the scatter of the next); then compounds 2 and 4 (each within the scatter of the next).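

In this assay, a high reading at this position does not depend on the 4-hydroxyphenyl group: with a number 6 percentage points higher from compound 2 to compound 4 (within the scatter), compound 2 and compound 4 cannot be told apart, while a number 30 percentage points higher from compound 3 to compound 4 (beyond the scatter) shows that replacing 3,4,5-trimethoxyphenyl with 2-chloropyridin-3-yl can raise growth inhibition beyond the scatter. A chlorine-bearing aromatic group does not by itself fix the level, as a number 23 percentage points higher from compound 1 to compound 4 (beyond the scatter) separates two such groups beyond the scatter. No measurement at hand accounts for these steps.

The compounds shown do not separate the contribution of the ring nitrogen from that of the chlorine in 2-chloropyridin-3-yl; a plain pyridin-3-yl and a 2-chlorophenyl would address this. From the compounds shown here alone, how an amine or a carboxylic acid on this aromatic ring would read also remains open.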